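The source may report more compounds than this note shows. Statements on the series, on what has been measured and on what is new or still open speak of the compounds shown alone.

Of the compounds shown here, two of a shared core have been measured in an assay on isolated protein for inhibition of RAC-alpha serine/threonine-protein kinase (Homo sapiens), read by mobility shift assay, tested at 30 uM; on this read-out lower numbers stand for less inhibition and higher numbers for more inhibition at the one concentration tested (going by the name of the read-out). Compound 1, `Nc1n[nH]c2cc(-c3cccs3)[nH]c(=O)c12`, carries a thiophen-2-yl group at one position of the core and a free ring nitrogen-hydrogen elsewhere; in this assay compound 1 gives 4%. Compound 2, `CC(C)(C)c1cc2nn(-c3ccccc3)c(N)c2c(=O)[nH]1`, carries a tert-butyl group at the corresponding position and a phenyl on the ring nitrogen; in this assay compound 2 gives 7%. Compound 2 holds the higher of the two numbers, but its gap to compound 1 lies within the scatter, so the two compounds cannot be ordered.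

Compound 3, `Nc1c2c(=O)[nH]c(-c3ccccn3)cc2nn1-c1ccccc1`, has not yet been measured in this assay. It differs from compound 2 in one place: pyridin-2-yl in place of tert-butyl on an aromatic carbon. For the measured compounds named here, no step between measured compounds of this kind exists, so any expectation rests on the low readings of compound 1 and compound 2 alone. Compound 3 is therefore expected to stay near the same low level, with a step from compound 2 of a number 1 percentage points higher from compound 2 to compound 3 (within the scatter), which would not reach beyond the scatter. The estimated value for compound 3 in this assay is 8%, within a range from 0% to 25%.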

Compound 3, a percentage reported as inhibition, at one concentration (the size of the read-out at that concentration, not a potency): 4%
Beside the measured number, compound 3's estimate is 4 percentage points above it, and the stated range covers the measured number.
By their numbers in this assay, from the lowest: compounds 1, 3 and 2 (each within the scatter of the next).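

In this assay, for the compounds shown here, the change of tert-butyl to pyridin-2-yl on an aromatic carbon, next to the ring nitrogen, gives a step of a number 3 percentage points lower from compound 2 to compound 3 (within the scatter) and is the first step measured at this position with the rest of the molecule held the same. It shows that exchanging a group with no ring and no hydrogen-bond acceptor for a six-membered aromatic ring with one hetero atom and a hydrogen-bond acceptor does not move the reading beyond the scatter, so this one exchange gives no sign that the reading depends on which of these two groups sits here. Nothing measured here accounts for this result, which rests on a single pair of compounds.

The compounds shown leave open whether a carboxylic acid, an amine or a longer alkyl chain on this aromatic carbon would carry the inhibition beyond the scatter. They also leave open whether a group other than phenyl on the ring nitrogen, such as a benzyl or a methyl, would change the reading when paired with either tert-butyl or pyridin-2-yl.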